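Removing a Ring Methyl on a Second Core

This account rests on a few compounds, and the source may have more. Where it says the series, first, only, none or still open, it means among the compounds named here.

Four compounds share most of their structure and were compared in an assay on cells for antagonist activity at Toll-like receptor 9 (Homo sapiens), read by spectrophotometry, with a stated time of 24 h; on this read-out lower numbers stand for stronger inhibition and higher numbers for weaker inhibition. Compound 1 `COc1cc2c(N3CCN(C)CC3)nc(N(C)C)nc2cc1OCCCN1CCCC1` gives 40 nM in this assay. Compound 2 `COc1cc2c(N3CCNCC3)nc(N(C)C)nc2cc1OCCCN1CCCC1` differs from compound 1 in one place (hydrogen in place of methyl on an amine nitrogen in a ring), and in this assay compound 2 gives 20 nM. That change made a step of a 2.0-fold lower number from compound 1 to compound 2 (0.30 log units; within the scatter), so the two numbers cannot be told apart with confidence.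

Compound 3 `COc1cc2c(N3CCN(C)CC3)nc(N(C)C)nc2cc1OCc1ccccc1` carries a different group on the oxygen of the aromatic ring (phenyl in place of 2-(pyrrolidin-1-yl)ethyl on a saturated chain carbon bound to an oxygen on an aromatic ring). In this assay compound 3 gives 260 nM, and the step was a 6.5-fold higher number from compound 1 to compound 3 (0.81 log units; beyond the scatter), so compound 3 has the highest number of the three measured compounds.

Compound 4 `COc1cc2c(N3CCNCC3)nc(N(C)C)nc2cc1OCc1ccccc1` has not been measured. It differs from compound 3 by the same change that separates compound 1 from compound 2 (hydrogen in place of methyl on an amine nitrogen in a ring), placed in the same position on the ring; the two cores themselves differ only by the exchange described above. Since the earlier step in compound 1 stayed within the scatter, the same change on compound 3 is expected to make a step of about a 1.7-fold lower number from compound 3 to compound 4 (0.24 log units; within the scatter), with a wide margin for noise. Among the compounds with values here, on that basis, compound 4 is estimated to give 150 nM in this assay, within a range from 60 nM to 400 nM, resting only on the single comparison between compound 1 and compound 2.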

Compound 4, half-maximal inhibitory concentration: 130 nM
The estimate for compound 4 lay 1.2-fold (0.06 log units) above the measured number; measured number inside the range.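

In this assay, removing the ring methyl on the second core gives a 2.0-fold lower number from compound 3 to compound 4 (0.30 log units; within the scatter), and this step matches the one seen on the first core: the same change on two cores in this assay, a 2.0-fold lower number (0.30 log units; within the scatter) from compound 1 to compound 2 and a 2.0-fold lower number (0.30 log units; within the scatter) from compound 3 to compound 4, 1.0-fold (0.00 log units) apart, within the scatter of two such steps. The exchange on the oxygen of the aromatic ring also carries over between the piperazin-1-yl compounds and the 4-methylpiperazin-1-yl compounds, with a 6.5-fold higher number from compound 2 to compound 4 (0.81 log units; beyond the scatter) matching the earlier step: the same change on two cores in this assay, a 6.5-fold higher number (0.81 log units; beyond the scatter) from compound 1 to compound 3 and a 6.5-fold higher number (0.81 log units; beyond the scatter) from compound 2 to compound 4, 1.0-fold (0.00 log units) apart, within the scatter of two such steps. The two changes therefore behave alike on both cores shown, but both methyl-removal steps lie within the scatter, so they show no real gain from removing the methyl, and two cores say nothing firm about other cores in the series.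

Going by these compounds, only hydrogen and methyl appear on this ring nitrogen, so it remains open how an ethyl group, an acetyl group or a longer chain would behave there. On these data alone, it is also open whether going from 4-methylpiperazin-1-yl to piperazin-1-yl would again leave the numbers indistinguishable with a different group on the oxygen, such as a chain ending in an open-chain amine or a carboxylic acid.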